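A few compounds are considered here, and "the series" means these few. Any claim that something is new, unique, unknown or untested is made for them only; others in the source may bear on it.

Measured compounds in a functional assay on UACC-62 cells (Homo sapiens) for inhibition, read by sulforhodamine B assay, with a stated time of 48 h, tested at 10 uM; a higher number here means more inhibition at the concentration tested (going by the name of the read-out), a lower number less inhibition:
compound 1 `c1ccc2c(-c3cn4ccnc4c(-c4ccc5ncn(C6CCCCC6)c5c4)n3)cccc2c1`: 16.7%
compound 2 `Fc1ccc(-c2cn3ccnc3c(-c3ccc4ncn(C5CCCCC5)c4c3)n2)cc1`: 31%
compound 3 `CC(=O)c1ccc(-c2cn3ccnc3c(-c3ccc4ncn(C5CCCCC5)c4c3)n2)cc1`: 18.5%

Compound 3 stands second highest of the three numbers in this assay. Its nearest neighbour is compound 1: the step of a number 1.8 percentage points higher from compound 1 to compound 3 (within the scatter) lies within the scatter, so the two are not separated. The furthest is compound 2: the step of a number 12.5 percentage points lower from compound 2 to compound 3 (beyond the scatter) lies beyond the scatter, a modest drop.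

Compound 4 `Fc1ccccc1-c1cn2ccnc2c(-c2ccc3ncn(C4CCCCC4)c3c2)n1` is the next member of the series and has not yet been measured in this assay. Relative to compound 3 the change is 2-fluorophenyl in place of 4-acetylphenyl on an aromatic carbon.

Among the measured compounds shown here, two measured steps bear on this change. The step of a number 12.5 percentage points lower from compound 2 to compound 3 (beyond the scatter) shows that exchanging the acetyl group of compound 3 for a fluoro group, at the same position as in compound 2, would be worth a modest rise. The step of a number 14.3 percentage points higher from compound 1 to compound 2 (beyond the scatter) shows the 4-fluorophenyl compound standing above the naphthalenyl compound by a similar modest amount. For the measured compounds named here, compound 4 carries its fluorine in the 2-fluorophenyl arrangement rather than the 4-fluorophenyl of compound 2, for which no measured step exists, so the gain is taken as uncertain and smaller.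

Compound 4 is therefore expected to give 25%, with a range of 12% to 40%. The expected step is a number 6.5 percentage points higher from compound 3 to compound 4 (within the scatter), a small rise not clearly beyond the scatter.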

Compound 4, a percentage reported as inhibition, at one concentration (the size of the read-out at that concentration, not a potency): 38.2%
Beside the measured number, compound 4's estimate is 13.2 percentage points below it; the measured number falls inside the stated range.
By their numbers in this assay, from the lowest: compounds 1 and 3 (each within the scatter of the next); then compounds 2 and 4 (each within the scatter of the next).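

In this assay, the aromatic carbon next to the ring nitrogen now has a second fluorophenyl reading, and the step of a number 7.2 percentage points higher from compound 2 to compound 4 (within the scatter) leaves the 2-fluorophenyl and 4-fluorophenyl groups unseparated, so the place of the fluorine on this phenyl ring does not register in this read-out. The steps of a number 19.7 percentage points higher from compound 3 to compound 4 (beyond the scatter) and a number 21.5 percentage points higher from compound 1 to compound 4 (beyond the scatter) confirm with a second compound what compound 2 alone had suggested: among these four compounds, both fluorophenyl compounds read modestly beyond the scatter of the 4-acetylphenyl and naphthalen-1-yl compounds, with no compound going against this split. Nothing available here explains why these groups read differently.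

The compounds shown leave open how a phenyl ring carrying a methoxy group, an amine or a carboxylic acid would read at this position, and whether an acetyl group placed as the fluorine is in compound 4 would stay level with compound 3. They also say nothing about potency, since each number is a reading at one concentration, or about changes elsewhere on the shared core.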